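This account rests on a few compounds, and the source may have more. Where it says the series, first, only, none or still open, it means among the compounds named here.

Measured in a functional assay on HeLa cells (Homo sapiens) for cytotoxicity, read by MTT assay, with a stated time of 72 h; a higher number here means a weaker inhibitor, a lower number a stronger inhibitor:
- compound 1 `O=C(Nc1nnc(-c2cccc(O)c2O)s1)c1ccc(Cl)cc1`: 13000 nM
- compound 2 `Cc1ccc(C(=O)Nc2nnc(-c3ccc(O)c(O)c3)s2)cc1`: 67100 nM
- compound 3 `O=C(Nc1nnc(-c2cccc(O)c2O)s1)C1CCCCC1`: 91600 nM

Compound 1 has the lowest number of the three and so is the strongest inhibitor here. Compound 2, at 67100 nM, lies well above it. The numbers for compound 2 and compound 3 are within the usual scatter of each other, so they cannot be told apart.

The next compound to be measured is compound 4 `O=C(Nc1nnc(-c2ccc(O)c(O)c2)s1)c1ccccc1`. It differs from compound 2 in one place: hydrogen in place of methyl on an aromatic carbon. In words, hydrogen takes the place of methyl on an aromatic carbon, turning 4-methylphenyl into phenyl.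

Among the compounds with values here, only one measured step bears on this change, and only loosely: a 7.0-fold higher number from compound 1 to compound 3 (0.85 log units; beyond the scatter). That step exchanges a whole group, not a single methyl, and it belongs to a different pair of compounds. It shows that the group on the carbonyl can move the number in this assay, and it was only modest even for that larger exchange. Within the data shown here, no measured step removes a methyl. A much smaller change is therefore expected here, with no shift beyond the scatter.

The estimated step is a 1.1-fold lower number from compound 2 to compound 4 (0.05 log units; within the scatter). For compound 4 the expected value is 60000 nM, with an estimated range from 25000 nM to 130000 nM.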

Compound 4, half-maximal inhibitory concentration: 23300 nM
For compound 4 the middle estimate is 2.6-fold (0.41 log units) above the measured one; the whole stated range lies above it.
By their numbers in this assay, from the lowest: compounds 1 and 4 (each within the scatter of the next); then compounds 2 and 3 (each within the scatter of the next).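

In this assay, taking away a single methyl from the 4-methylphenyl group, so that plain phenyl remains, gives a 2.9-fold lower number from compound 2 to compound 4 (0.46 log units; beyond the scatter). Within the data shown here, this is the first measured step confined to this one place, an aromatic carbon para to a large group, and it shows that the loss of one carbon atom there is enough to carry the number beyond the scatter. Among these compounds, until now the only measured change on this side of the amide was the exchange of a whole group, so this pair shows that a far smaller edit can also register, and that here hydrogen goes with the lower number and methyl with the higher; no measurement available here accounts for this shift.

As far as these compounds go, what remains open is how other groups at this same place on the six-membered aromatic ring would compare with hydrogen and methyl, for example an ethyl group, a methoxy group, an amine or a carboxylic acid. From the compounds shown here alone, it is also open whether the same change would give a step of similar size on the core of compound 1, where the two hydroxyl groups are placed differently.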